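Ethynyl replaces thiophen-3-yl: an expected gain

The compounds below may be only part of what the source reports. "The series", "measured", "known", "first", "only" and "open" are said of these compounds alone.

Values in a functional assay on K562 cells (Homo sapiens), read by MTT assay, with a stated time of 72 h (a higher number here means a weaker inhibitor, a lower number a stronger inhibitor), are as follows
Compound 1 `C#Cc1cn([C@@H]2O[C@H](CO)[C@@H](O)[C@H]2O)c2ncnc(OC)c12` gives 380 nM as a number
Compound 2 `COc1nc(N)nc2c1c(-c1ccco1)cn2[C@@H]1O[C@H](CO)[C@@H](O)[C@H]1O` gives > 20000 nM as a limit
Compound 3 `COc1nc(N)nc2c1c(-c1ccsc1)cn2[C@@H]1O[C@H](CO)[C@@H](O)[C@H]1O` gives > 20000 nM as a limit

Compound 3 stands at the limit of > 20000 nM in this assay, at which 2 of the 3 values shown sit, and so offers only a limit as a starting point. Compound 4 `C#Cc1cn([C@@H]2O[C@H](CO)[C@@H](O)[C@H]2O)c2nc(N)nc(OC)c12` puts ethynyl in place of thiophen-3-yl on an aromatic carbon, and the change is ethynyl in place of thiophen-3-yl on an aromatic carbon in full. Among the measured compounds shown here, the only measured step is a step that the two limits leave unreadable from compound 2 to compound 3 and it offers no size to carry over. Compound 1 also carries ethynyl and gives 380 nM on a core that differs from that of compound 3, which points towards a stronger inhibitor in this assay without fixing the size. A step of an at least 6.6-fold lower number from compound 3 to compound 4 (0.82 log units; beyond the scatter) is therefore expected. For compound 4 the value is estimated at 3000 nM with 300 nM to 20000 nM as the expected range.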

Compound 4, half-maximal inhibitory concentration: > 20000 nM
Compound 4: only a limit was reported (the forecaster's own chance of this, stated with the estimate: 25%); middle value at least 6.6-fold (0.82 log units) from the limit.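

The value of compound 4 is a limit, not a number, and it is the same limit as for the other amino-bearing compounds: the limit of > 20000 nM in this assay, at which 3 of the 4 values shown sit. In this assay, amino in place of hydrogen on an aromatic carbon gives an at least 52-fold higher number from compound 1 to compound 4 (1.72 log units; beyond the scatter), so with ethynyl in place, this one change separates a measurable value from a limit. The steps among compounds 2, 3 and 4 cannot be read, so ethynyl, thiophen-3-yl and furan-2-yl cannot be ranked on this core.

As far as these compounds go, it remains open whether furan-2-yl or thiophen-3-yl would give a number on the core of compound 1. Also open, from the compounds shown here alone, is whether a nitrile or methyl at this position would give one on the amino-bearing core.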